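The compounds below may be only part of what the source reports. "The series", "measured", "known", "first", "only" and "open" are said of these compounds alone.

Of the compounds shown here, two built on a shared core have been measured in a functional assay on A549 cells (Homo sapiens) for antiproliferative activity, read by MTT assay; on this read-out higher numbers stand for weaker inhibition and lower numbers for stronger inhibition. Compound 1 `C#CCN(c1nc2ccc(F)cc2s1)c1nc2ccc(OC)cc2s1` gives 24500 nM in this assay. Compound 2 `COc1ccc2nc(N(Cc3cc(-c4ccc(OC(F)(F)F)cc4)no3)c3nc4ccc(F)cc4s3)sc2c1` gives 37100 nM in this assay. Of these two numbers compound 2 carries the higher one, and compound 1 stands nearest to it; the gap between them falls within the scatter of repeated measurements, so the two cannot be told apart on this evidence, and both sit at weak inhibition.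

Compound 3 `COc1ccc2nc(N(Cc3cc(-c4cc(OC)c(OC)c(OC)c4)no3)c3nc4ccc(F)cc4s3)sc2c1` has not yet been measured. It differs from compound 2 in a single place: 3,4,5-trimethoxyphenyl in place of 4-(trifluoromethoxy)phenyl on an aromatic carbon. Among the measured compounds shown here, no step between measured compounds touches this position, so nothing among the measured pairs shows what such an exchange does. Compound 3 is therefore expected to show a step of a 1.7-fold lower number from compound 2 to compound 3 (0.23 log units; within the scatter) that could go in either direction and most likely stays within the scatter. The estimate for compound 3 is 22000 nM, with a range from 6000 nM to 70000 nM.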

Compound 3, half-maximal inhibitory concentration: 61900 nM
Compound 3: middle estimate off by 2.8-fold (0.45 log units), on the low side, within the range that was stated.
By their numbers in this assay, from the lowest: compounds 1, 2 and 3 (each within the scatter of the next, the first and the last beyond it).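

In this assay, among the compounds shown here, this is the first exchange seen on this aromatic carbon of the five-membered ring, and 3,4,5-trimethoxyphenyl in place of 4-(trifluoromethoxy)phenyl gives a 1.7-fold higher number from compound 2 to compound 3 (0.22 log units; within the scatter), so compound 2 and compound 3 cannot be told apart. The two groups differ clearly on paper, since the entering one carries 3 hydrogen-bond acceptors where the leaving one carries 1 and it swaps fluorine for more oxygen, yet this change leaves both compounds at weak inhibition with no difference that can be read. Nothing measured on these compounds offers an explanation for this result.

From the compounds shown here alone, what an amine or a carboxylic acid on this phenyl ring would do remains open, as does the effect of a plain phenyl or a longer chain in its place. It is also open whether any group at this position can bring inhibition out of the weak range, since the two substituted phenyl groups shown here do not separate.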